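The source may hold more compounds than are shown below. What is called first, only, known or untested is meant among the compounds shown, and "the series" means these compounds.

In a functional assay (lung parenchyma) for displacement of a labelled ligand, with Cavia porcellus as the target (a lower number here means a stronger inhibitor, a higher number a weaker inhibitor), compound 1 (`COc1cc(C(=O)NS(=O)(=O)c2ccccc2C)ccc1Cc1nn(C)c2ccc(C(=O)NCC3CCCC3)cc12`) gives 1.87 nM and compound 3 (`COc1cc(C(=O)NS(=O)(=O)c2ccccc2C)ccc1Cc1cn(C)c2ccc(C(=O)NCC3CCCC3)cc12`) gives 3.21 nM, two values within the scatter of each other, while compound 2 (`COc1cc(C(=O)NS(=O)(=O)c2ccccc2C)ccc1Cc1cn(C)c2ccc(NC(=O)CC3CCCC3)cc12`) gives 0.3 nM, a clearly lower number than either. Compound 4 (`CCN(CC)C(=O)CCn1cc(Cc2ccc(C(=O)NS(=O)(=O)c3ccccc3C)cc2OC)c2cc(C(=O)NCC3CCCC3)ccc21`) differs from compound 3 by (diethylcarbamoyl)methyl in place of hydrogen on a saturated chain carbon bound to an aromatic nitrogen. Going by the values given here, no measured step touches that place. The only one, an 11-fold higher number from compound 2 to compound 3 (1.03 log units; beyond the scatter), exchanges the amide elsewhere on the core and shows only how far a single change can move the number. No shift beyond the scatter is therefore expected, in either direction, though with wide uncertainty. The expected step is a 1.3-fold lower number from compound 3 to compound 4 (0.11 log units; within the scatter). For compound 4 the estimated value is 2.5 nM, with an expected range from 0.6 nM to 10 nM.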

Compound 4, inhibition constant: 0.43 nM
Compound 4: middle estimate off by 5.8-fold (0.76 log units), on the high side, and the stated range ends above it.
By their numbers in this assay, from the lowest: compounds 2 and 4 (each within the scatter of the next); then compounds 1 and 3 (each within the scatter of the next).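

Of the compounds shown, only compound 4 changes this saturated chain carbon bound to an aromatic nitrogen, and in this assay the change from hydrogen to (diethylcarbamoyl)methyl gives a 7.5-fold lower number from compound 3 to compound 4 (0.87 log units; beyond the scatter). The place therefore takes a group of this size, and the number moves in the stronger direction. Nothing measured here accounts for that shift.

On these data alone, whether the diethylcarbamoyl end or the chain alone carries it stays open, as a simple longer alkyl chain, a carboxylic acid or a diethylamine at this place would tell these apart. Also open, as far as these compounds go, is whether the same change would act alike on compound 2.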